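The source may hold more compounds than are shown below. What is called first, only, known or untested is meant among the compounds shown, and "the series" means these compounds.

The measured compounds are:
compound 1, `COc1ccc(C(=O)CSc2nc3[nH]c(=O)n(C)c(=O)c3[nH]2)cc1`, 6700 nM
compound 2, `Cn1c(=O)[nH]c2nc(SCC(=O)c3ccc(Cl)cc3)[nH]c2c1=O`, 7200 nM
compound 3, `COc1ccc(/C(CSc2nc3[nH]c(=O)n(C)c(=O)c3[nH]2)=N\O)cc1`, 1700 nM

All three were tested in a functional assay on HT-29 cells (Homo sapiens) for inhibition, read by MTT assay, with a stated time of 48 h; on this read-out higher numbers stand for weaker inhibition and lower numbers for stronger inhibition. Compound 1 and compound 2 differ in one place: chloro in place of methoxy on an aromatic carbon. This change gave a 1.1-fold higher number from compound 1 to compound 2 (0.03 log units; within the scatter), so the two values cannot be told apart. Compound 3 carries a different core; how it differs from compound 1 is not broken down here, but in this assay compound 3 gives 1700 nM, the lowest of the three numbers. Compound 4, `Cn1c(=O)[nH]c2nc(SC/C(=N/O)c3ccc(Cl)cc3)[nH]c2c1=O`, has not yet been measured. It stands to compound 3 as compound 2 stands to compound 1: chloro in place of methoxy on an aromatic carbon. The place of the change is the same in both pairs, so this is the same change made on another core. Because the same change gave a 1.1-fold higher number from compound 1 to compound 2 (0.03 log units; within the scatter), a step of similar size is expected for compound 4, namely a 1.1-fold higher number from compound 3 to compound 4 (0.05 log units; within the scatter). The expected value for compound 4 in this assay is 1900 nM, with a likely range from 900 nM to 4000 nM.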

Compound 4, half-maximal inhibitory concentration: 1800 nM
Beside the measured number, compound 4's estimate is 1.1-fold (0.02 log units) above it, within the range that was stated.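

In this assay, putting chloro in place of methoxy on the aromatic carbon gives a 1.1-fold higher number from compound 3 to compound 4 (0.02 log units; within the scatter), so on this core too the two groups cannot be told apart. Set beside the earlier pair, the change behaves alike on both cores, making no readable difference on either: the same change on two cores in this assay, a 1.1-fold higher number (0.03 log units; within the scatter) from compound 1 to compound 2 and a 1.1-fold higher number (0.02 log units; within the scatter) from compound 3 to compound 4, 1.0-fold (0.01 log units) apart, within the scatter of two such steps This shows that the result carried over in these two pairs of compounds, but it does not show that the same would hold on any other core or in any other test, and it gives no reason why the two groups match.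

The compounds shown leave open whether a group of a different kind on that aromatic carbon, such as an amine, a carboxylic acid or a longer alkyl chain, would give a number beyond the scatter. They also leave open whether methoxy and chloro would still match on a ring carbon that is not para to the large group.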